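Expected Cytotoxicity of Compound 4 after an Aryl Swap

This account rests on a few compounds, and the source may have more. Where it says the series, first, only, none or still open, it means among the compounds named here.

Measured compounds:
compound 1 `O=C1OC[C@H](Cc2ccccc2)[C@H]1Cc1ccc(O)cc1`: 88000 nM
compound 2 `COc1ccccc1C[C@H]1COC(=O)[C@@H]1Cc1ccc(Cl)c(Cl)c1`: 14000 nM
compound 3 `CCCCc1ccc(C[C@H]2COC(=O)[C@@H]2Cc2ccc(Cl)c(Cl)c2)cc1`: 9400 nM

All three were tested in a functional assay on HL-60 cells (Homo sapiens) for cytotoxicity, read by WST assay, with a stated time of 48 h; on this read-out higher numbers stand for an effect only at larger amounts of compound and lower numbers for an effect already at smaller amounts. Compound 2 stands second highest of the three numbers. Its nearest neighbour is compound 3, whose value lies within the usual scatter of repeated measurements, so the two cannot be told apart. Its furthest is compound 1, which gives a higher number, and that gap lies beyond the scatter.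

Compound 4 `Cc1ccc(C[C@H]2COC(=O)[C@@H]2Cc2ccc(Cl)c(Cl)c2)cc1C` has not been measured. It differs from compound 2 in one place:
3,4-dimethylphenyl in place of 2-methoxyphenyl on a saturated chain carbon bound to a saturated ring carbon

Among the measured compounds shown here, no pair of measured compounds differs in just one place, so no measured step can guide this change directly. Compound 3 carries a butyl-bearing phenyl at the same place and sits close to compound 2, which suggests a small step, if any, and none clearly beyond the scatter, perhaps slightly toward lower numbers. Compound 4 is therefore expected to give 11000 nM in this assay, with a range from 4000 nM to 30000 nM. That estimate means a step of a 1.3-fold lower number from compound 2 to compound 4 (0.10 log units; within the scatter).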

Compound 4, half-maximal effective concentration: 16000 nM
Beside the measured number, compound 4's estimate is 1.5-fold (0.16 log units) below it, and the stated range covers the measured number.
By their numbers in this assay, from the lowest: compounds 3, 2 and 4 (each within the scatter of the next); then compound 1.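

In this assay, among the compounds shown here, putting 3,4-dimethylphenyl in place of 2-methoxyphenyl on a saturated chain carbon bound to a saturated ring carbon gives a 1.1-fold higher number from compound 2 to compound 4 (0.06 log units; within the scatter), the only comparison here in which two measured compounds differ in just one place. At this position, then, an aryl group without the hydrogen-bond acceptor counted in 2-methoxyphenyl gives a number that cannot be told apart from that of compound 2. No measurement here explains why the exchange leaves no readable difference.

The compounds shown leave open whether a different kind of group at this place, such as an amine or a carboxylic acid on the phenyl ring, would produce a step beyond the scatter. From the compounds shown here alone, whether the same aryl swap would also give so small a step on the core of compound 1 remains open too.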